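The source may report more compounds than this note shows. Statements on the series, on what has been measured and on what is new or still open speak of the compounds shown alone.

Measured compounds:
Compound 1 `O=S(=O)(Nc1ccc(NS(=O)(=O)c2ccc(Cl)cc2)cc1)c1ccc(F)cc1`: in an assay for inhibition of liver carboxylesterase 1 (Homo sapiens), read by spectrophotometry (a lower number here means a stronger inhibitor, a higher number a weaker inhibitor), compound 1 gives > 100000 nM, which is a limit of the assay.
Compound 2 `Cc1ccc(C(=O)O)cc1S(=O)(=O)Nc1ccc(NS(=O)(=O)c2ccc(F)cc2)cc1`: in this assay compound 2 gives > 100000 nM, also a limit of the assay.

Among the measured compounds shown here, compound 2 thus stands at the limit of > 100000 nM in this assay, at which 2 of the 2 values shown sit, and the only measured step, a step that the two limits leave unreadable from compound 1 to compound 2, cannot be given a size. Compound 3 `CNC(=O)c1ccc(S(=O)(=O)Nc2ccc(NS(=O)(=O)c3ccc(F)cc3)cc2)cc1` carries the change (4-(methylcarbamoyl)phenyl in place of 5-carboxy-2-methylphenyl on a sulfonyl sulfur). For the measured compounds named here, the one measured step touches the same sulfonyl sulfur, but its size is unreadable, so it offers no number to carry over; all it shows is that both groups tried so far on that sulfur leave the value at the limit. The expectation for compound 3 in this assay is therefore again a value at or near the limit, the expected step being a step that the limit leaves unreadable from compound 2 to compound 3. Compound 3 is estimated at 150000 nM, within a range from 30000 nM to 1000000 nM, with a reported limit more likely than a number.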

Compound 3, inhibition constant: > 100000 nM
Compound 3 ended at the assay's limit; the forecaster's own chance of this, stated with the estimate: 75%; the middle value is on the limit's open side.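

In this assay the steps among compound 1, compound 2 and compound 3 cannot be read, all three values being limits: the limit of > 100000 nM in this assay, at which 3 of the 3 values shown sit. Left open is whether any group on this sulfonyl sulfur gives a numerical inhibition constant, and so how large any such step would be.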